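A Methyl Group Tested Against a Limit

A few compounds are considered here, and "the series" means these few. Any claim that something is new, unique, unknown or untested is made for them only; others in the source may bear on it.

Compound 1, `c1ccc(-c2n[nH]cc2N2CCNCC2)cc1`, in an assay on isolated protein for binding affinity to 5-hydroxytryptamine receptor 1E (Homo sapiens) (a higher number here means a weaker inhibitor, a lower number a stronger inhibitor), compound 1 gives > 10000 nM.
Compound 2, `Fc1cccc(-c2n[nH]cc2N2CCNCC2)c1`, gives > 10000 nM.

Compound 1 stands only at a limit: its value in this assay is a limit of the assay, not a number. The value of compound 2 is likewise a limit. Within the data shown here, the one measured step, a step that the two limits leave unreadable from compound 1 to compound 2, is therefore unreadable in size and direction. Compound 3, `Cc1ccc(-c2n[nH]cc2N2CCNCC2)cc1`, differs from compound 1 by methyl in place of hydrogen on an aromatic carbon. Among the measured compounds shown here, no measured step bears directly on this change; the only evidence available is the limit of > 10000 nM in this assay, at which 2 of the 2 values shown sit, which leaves the effect of any small change on the core unresolved. With both known values sitting at the limit, compound 3 is expected to stay at the limit as well, and the expected step that the limit leaves unreadable from compound 1 to compound 3 is set at no change beyond the scatter. Compound 3 is accordingly estimated at 15000 nM, with a range from 5000 nM to 50000 nM.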

Compound 3, inhibition constant: > 10000 nM
Compound 3 ended at the assay's limit; the forecaster's own chance of this, stated with the estimate: 85%; the middle value does not contradict the limit.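

Compound 3 gives > 10000 nM, which is a limit of the assay and not a number. Compound 1 also stands at a limit, and the step between these two compounds cannot be read. The compounds shown leave open how any small change on the shared core acts in this assay: the limit of > 10000 nM in this assay, at which 3 of the 3 values shown sit.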